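This account rests on a few compounds, and the source may have more. Where it says the series, first, only, none or still open, it means among the compounds named here.

Measured so far:
Compound 1, `COc1ccc(/C=N\NC(=S)NC(C)(C)CCC[C@](C)(O)[C@@H]2CC=C(C)CC2)cc1`: 220 nM
Compound 2, `CC1=CC[C@@H]([C@@](C)(O)CCCC(C)(C)NC(=S)N/N=C\c2ccc(N(C)C)cc2)CC1`: 80 nM

Both compounds share one core and differ only in the group on the aromatic ring. Among the compounds with values here, in a functional assay on K562 cells (Homo sapiens) for cytotoxicity, read by sulforhodamine B assay (a higher number here means a weaker inhibitor of growth, a lower number a stronger inhibitor of growth), compound 2 gives the lower of the two numbers, and the step of a 2.8-fold lower number from compound 1 to compound 2 (0.44 log units; beyond the scatter) is the single measured change in this set. Compound 3, `CC1=CC[C@@H]([C@@](C)(O)CCCC(C)(C)NC(=S)N/N=C\c2cccc(Cl)c2)CC1`, has not yet been measured; its difference from compound 2 is 3-chlorophenyl in place of 4-(dimethylamino)phenyl on a carbon with a double bond to nitrogen. Within the data shown here, the one measured step bears only loosely on this change, since it exchanged one group for another at a different position on the same ring, and nothing measured holds a chlorine-bearing ring. Among the measured compounds shown here, with 4-(dimethylamino)phenyl giving the lower number so far and the methoxy analogue the higher, the third-person expectation is that compound 3 returns toward or beyond the number of compound 1, an expected step of a 3.1-fold higher number from compound 2 to compound 3 (0.49 log units; beyond the scatter). Compound 3 is therefore estimated at 250 nM, with a range from 100 nM to 700 nM.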

Compound 3, concentration for 50% growth inhibition: 30 nM
For compound 3 the middle estimate is 8.3-fold (0.92 log units) above the measured one, outside the stated range (below it).
By their numbers in this assay, from the lowest: compound 3; then compound 2; then compound 1.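

In this assay, 3-chlorophenyl in place of 4-(dimethylamino)phenyl on a carbon with a double bond to nitrogen gives a 2.7-fold lower number from compound 2 to compound 3 (0.43 log units; beyond the scatter), and the replacement of 4-methoxyphenyl gives a 7.3-fold lower number from compound 1 to compound 3 (0.87 log units; beyond the scatter). Compound 3 thus has the lowest number of the three, which shows that a hydrogen-bond acceptor on the aromatic group is not needed for a low number here: 3-chlorophenyl has none, while 4-(dimethylamino)phenyl has one. No measurement is available to explain this ordering.

On these data alone, what remains open is whether the lower number follows from the chlorine itself or from where it sits on the ring, since compound 3 differs from compound 1 and compound 2 in both. An unsubstituted phenyl ring, or a ring carrying bromine or a nitrile, would help to separate these readings.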